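Compound 4: piperidin-4-yl in place of (piperidin-4-yl)oxy

The compounds below may be only part of what the source reports. "The series", "measured", "known", "first", "only" and "open" are said of these compounds alone.

In an ADME assay on microsomes from liver (Homo sapiens) for metabolic stability, read by LC-MS, tested at 1 uM (on this read-out lower numbers stand for slow clearance and higher numbers for fast clearance), compound 1 (`N[C@H]1CC[C@H](Oc2ccc([C@H]3CC[C@]4(CC3)OOC3(O4)C4CC5CC(C4)CC3C5)cc2)CC1`) gives < 7 mL.min-1.g-1 and this is a limit, not a number. Compound 2 (`NCCCOc1ccc([C@H]2CC[C@]3(CC2)OOC2(O3)C3CC4CC(C3)CC2C4)cc1`) gives < 7 mL.min-1.g-1 and this is also a limit. Compound 3 (`c1cc([C@H]2CC[C@]3(CC2)OOC2(O3)C3CC4CC(C3)CC2C4)ccc1OCCOC1CCNCC1`) gives < 7 mL.min-1.g-1 and this too is a limit. Compound 3 thus stands with the other two at the limit of < 7 mL.min-1.g-1 in this assay, at which 3 of the 3 values shown sit, and has no number of its own.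

Compound 4 (`c1cc([C@H]2CC[C@]3(CC2)OOC2(O3)C3CC4CC(C3)CC2C4)ccc1OCCC1CCNCC1`) carries piperidin-4-yl in place of (piperidin-4-yl)oxy on a saturated chain carbon, two bonds along the chain from an oxygen on an aromatic ring. The nearest guide is a step that the two limits leave unreadable from compound 2 to compound 3 at the same place, and it gives no size. Among the measured compounds shown here, neither a step that the two limits leave unreadable from compound 1 to compound 2 nor a step that the two limits leave unreadable from compound 1 to compound 3 gives a size, so the series offers no measured step to scale from. All that can be said is that these three compounds share one limit.

The expected result is a step that the limit leaves unreadable from compound 3 to compound 4 in this assay with no direction beyond the scatter. Compound 4 is estimated at 6 mL.min-1.g-1 with an expected range from 3 mL.min-1.g-1 to 12 mL.min-1.g-1 and may well turn out to be only a limit.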

Compound 4, intrinsic clearance in microsomes: < 7 mL.min-1.g-1
Compound 4 ended at the assay's limit; the forecaster's own chance of this, stated with the estimate: 75%; the middle value is on the limit's open side.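

Compound 4 joins compound 1, compound 2 and compound 3 in this assay, so no step among these compounds can be read, and all that stands is a shared limit: the limit of < 7 mL.min-1.g-1 in this assay, at which 4 of the 4 values shown sit. The compounds shown leave open what number each would carry, and so whether piperidin-4-yl in place of (piperidin-4-yl)oxy alters intrinsic clearance in microsomes at all.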